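The compounds below may be only part of what the source reports. "The series", "measured", "known", "first", "only" and "open" are said of these compounds alone.

- compound 1 `CCSc1ncnc2c1nnn2[C@@H]1O[C@H](CO)[C@@H](O)[C@H]1O` gives 0.1 uM
- compound 2 `CCOc1ncnc2c1nnn2[C@@H]1O[C@H](CO)[C@@H](O)[C@H]1O` gives 0.1 uM
- compound 3 `CCCCNc1ncnc2c1nnn2[C@@H]1O[C@H](CO)[C@@H](O)[C@H]1O` gives 0.3 uM

In a functional assay on HEp-2 cells (Homo sapiens) for inhibition (a higher number here means that more compound is needed for the effect, a lower number that less compound is needed), compound 3 stands highest of the three, at 0.3 uM, and so is the least potent so far. Compound 4 `CC(C)=CCNc1ncnc2c1nnn2[C@@H]1O[C@H](CO)[C@@H](O)[C@H]1O` alters its chain: 2-methylprop-1-en-1-yl in place of propyl on a saturated chain carbon bound to a nitrogen on an aromatic ring, which also reads butyl to 3-methylbut-2-en-1-yl. The nearest evidence is a 3.0-fold higher number from compound 1 to compound 3 (0.48 log units; beyond the scatter) and a 3.0-fold higher number from compound 2 to compound 3 (0.48 log units; beyond the scatter). Going by the values given here, both swapped the whole group on the aromatic carbon, whereas here the attached nitrogen stays, and no measured pair tests a chain change alone. A smaller step is therefore expected, with no clear direction and nothing beyond the scatter: no change at the digits printed from compound 3 to compound 4 (within the scatter). Compound 4 is estimated at 0.3 uM, with an expected range from 0.1 uM to 1 uM.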

Compound 4, concentration for half-maximal effect: < 3 uM
Compound 4: no number, only a limit; the forecaster's own chance of this, stated with the estimate: 3%; the middle value is on the limit's open side.
By their numbers in this assay, from the lowest: compounds 1 and 2 (each within the scatter of the next); then compound 3.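

In this assay compound 4 gives < 3 uM, which is a limit and not a number, so its steps from compound 1, compound 2 and compound 3 cannot be read. From the compounds shown here alone, whether changing butyl to 3-methylbut-2-en-1-yl shifts the number at all remains open.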